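A few compounds are considered here, and "the series" means these few. Any claim that something is new, unique, unknown or untested is made for them only; others in the source may bear on it.

Measured compounds:
- compound 1 `COc1cc(-c2ccnc3cc(-c4ccc5cc[nH]c5c4)nn23)cc(OC)c1OC`; in a functional assay on A549 cells (Homo sapiens) for inhibition, read by CCK-8 assay, with a stated time of 48 h (on this read-out higher numbers stand for weaker inhibition and lower numbers for stronger inhibition), compound 1 gives 170 nM
- compound 2 `COc1cc(-c2ccnc3cc(-c4ccccc4)nn23)cc(OC)c1OC`; in this assay compound 2 gives 208 nM
- compound 3 `COc1cc(-c2ccnc3cc(-c4ccc5c(ccn5C)c4)nn23)cc(OC)c1OC`; in this assay compound 3 gives 15 nM

Compound 3 stands with the lowest number of the three, and both of its steps from the others are beyond the scatter: an 11-fold lower number from compound 1 to compound 3 (1.05 log units; beyond the scatter) and a 14-fold lower number from compound 2 to compound 3 (1.14 log units; beyond the scatter). Compound 1 and compound 2 sit together, the step of a 1.2-fold higher number from compound 1 to compound 2 (0.09 log units; within the scatter) being within the scatter.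

Compound 4 `COc1cc(-c2ccnc3cc(-c4ccc(C(F)(F)F)cc4)nn23)cc(OC)c1OC` is the next compound to be measured. The change from compound 3 is 4-(trifluoromethyl)phenyl in place of 1-methyl-1H-indol-5-yl on an aromatic carbon.

For the measured compounds named here, the steps that bear on this are the two that lead into compound 3: a 14-fold lower number from compound 2 to compound 3 (1.14 log units; beyond the scatter) and an 11-fold lower number from compound 1 to compound 3 (1.05 log units; beyond the scatter), both large. Compound 4 carries a plain phenyl ring bearing a trifluoromethyl group, closer in kind to the phenyl of compound 2 than to the 1-methyl-1H-indol-5-yl of compound 3. Going by the values given here, no measured step tells what the trifluoromethyl group itself contributes, so the expectation leans on the phenyl of compound 2. A large step upward in this assay is therefore expected, back toward the numbers of compound 1 and compound 2. Compound 4 is expected to give about 150 nM, within 40 nM to 600 nM, an expected step of a 10-fold higher number from compound 3 to compound 4 (1.00 log units; beyond the scatter).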

Compound 4, half-maximal inhibitory concentration: 2070 nM
Estimate against measurement, compound 4: 14-fold (1.14 log units) below; measured number above the stated range.
By their numbers in this assay, from the lowest: compound 3; then compounds 1 and 2 (each within the scatter of the next); then compound 4.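

In this assay, for the compounds shown here, the step (a 10-fold higher number from compound 2 to compound 4 (1.00 log units; beyond the scatter)) gives the first reading of a substituent on the phenyl ring at this aromatic carbon: trifluoromethyl in place of hydrogen moves the number beyond the scatter, whereas the exchange of phenyl and 1H-indol-6-yl stayed within it. The 4-(trifluoromethyl)phenyl compound also stands on the high side of both indole compounds (a 12-fold higher number from compound 1 to compound 4 (1.09 log units; beyond the scatter); a 140-fold higher number from compound 3 to compound 4 (2.14 log units; beyond the scatter)), so this place separates groups of equal heavy-atom count over a much wider span than the first three compounds showed. No measurement on hand bears on the reason for these steps.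

From the compounds shown here alone, whether the rise belongs to trifluoromethyl itself or would follow any group on that phenyl ring remains open, and a methoxy group, an amine or a carboxylic acid at the same ring carbon would address this. Also open, going by these compounds, is how much of the low number of compound 3 comes from the methyl on the indole nitrogen and how much from attachment through the 5-yl rather than the 6-yl carbon, as compound 1 and compound 3 differ in both.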